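Methyl in Place of Chloro on an Aromatic Carbon

A few compounds are considered here, and "the series" means these few. Any claim that something is new, unique, unknown or untested is made for them only; others in the source may bear on it.

Compound 2 `COc1ccc(-n2nc(Sc3ccc(Cl)cc3)cc(CC[C@@H](C)NC(=O)[C@H]3CNC[C@@H]3c3ccc(Cl)cc3)c2=O)cc1` stands highest of the two numbers measured in a functional assay with Melanocortin receptor 4 (Homo sapiens) as the target, read by cAMP accumulation (on this read-out higher numbers stand for an effect only at larger amounts of compound and lower numbers for an effect already at smaller amounts), at 230 nM. Among the compounds with values here, compound 1 `COc1ccc(-n2nc(Sc3ccc(Cl)cc3)cc(CC[C@@H](C)NC(=O)[C@H]3CNC[C@@H]3c3ccc(F)cc3)c2=O)cc1` gives 110 nM in this assay, and the step of a 2.1-fold higher number from compound 1 to compound 2 (0.32 log units; beyond the scatter) is the only measured change at this position. Compound 3 `COc1ccc(-n2nc(Sc3ccc(Cl)cc3)cc(CC[C@@H](C)NC(=O)[C@H]3CNC[C@@H]3c3ccc(C)cc3)c2=O)cc1` differs from compound 2 by methyl in place of chloro on an aromatic carbon. Within the data shown here, no measured step exchanges chloro for methyl, so the fluoro-to-chloro step is only a loose guide, and for compound 3 a step no larger than that, in either direction, is expected, namely a 1.2-fold lower number from compound 2 to compound 3 (0.06 log units; within the scatter). Compound 3 is estimated at 200 nM, within a range from 90 nM to 450 nM.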

Compound 3, half-maximal effective concentration: 750 nM
For compound 3 the middle estimate is 3.8-fold (0.57 log units) below the measured one; the whole stated range lies below it.
By their numbers in this assay, from the lowest: compound 1; then compound 2; then compound 3.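

Replacing chloro with methyl gives a 3.3-fold higher number from compound 2 to compound 3 (0.51 log units; beyond the scatter) in this assay, so the position also responds to a group that is not a halogen. Among these para substituents, the methyl of compound 3 gives the highest number, and the fluoro-to-methyl exchange spans a 6.8-fold higher number from compound 1 to compound 3 (0.83 log units; beyond the scatter). No measurement offered here explains this difference. The compounds shown leave open how a methoxy group, a trifluoromethyl group or an amine at this place would read, and whether any group would give a lower number than the fluoro of compound 1.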